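The compounds below may be only part of what the source reports. "The series", "measured", "known", "first", "only" and "open" are said of these compounds alone.

Measured compounds:
- compound 1 `O=C(/C=C\c1ccccc1)N1N=C(c2ccncc2)OC1c1c[nH]c2ccccc12`: > 30 ug/mL
- compound 2 `COc1ccc(/C=C\C(=O)N2N=C(c3ccncc3)OC2c2c[nH]c3ccccc23)cc1`: > 30 ug/mL

In an ADME assay on PANC-1 cells (Homo sapiens) for cytotoxicity, read by MTT assay, with a stated time of 48 h (on this read-out lower numbers stand for stronger inhibition of growth and higher numbers for weaker inhibition of growth), compound 1 gives > 30 ug/mL, which is a limit of the assay rather than a number. Compound 2 likewise gives > 30 ug/mL in this assay, again only a limit. So compound 2 stands at the upper edge of what this assay reports, with no number of its own. Among the compounds with values here, the single measured step, a step that the two limits leave unreadable from compound 1 to compound 2, cannot be sized because the limit of > 30 ug/mL in this assay, at which 2 of the 2 values shown sit, covers both of its ends.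

Compound 3 `O=C(/C=C\c1cccc(F)c1)N1N=C(c2ccncc2)OC1c1c[nH]c2ccccc12` differs from compound 2 in one place: 3-fluorophenyl in place of 4-methoxyphenyl on a double-bonded chain carbon bound to a double-bonded chain carbon. Within the data shown here, no measured step addresses this change, and the only step that exists, from compound 1 to compound 2, is unreadable. There is therefore no basis in these data for expecting the step that the limit leaves unreadable from compound 2 to compound 3 to reach beyond the usual scatter in either direction; the estimate rests on the limits alone. Compound 3 is expected to give about 40 ug/mL in this assay, with an estimated range from 15 ug/mL to 100 ug/mL, and most likely to be reported only as a limit again.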

Compound 3, concentration for 50% growth inhibition: > 30 ug/mL
Compound 3: a limit, no number (the forecaster's own chance of this, stated with the estimate: 75%); the middle value lies beyond the limit too.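

Neither the step from compound 2 to compound 3 nor the one from compound 1 to compound 3 can be read in this assay, because compounds 1, 2 and 3 all end at the same limit rather than at a number: the limit of > 30 ug/mL in this assay, at which 3 of the 3 values shown sit.

The compounds shown leave open how strongly any of them inhibits growth, and whether the methoxy or fluoro changes alter it at all.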